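Sulfonamide aryl variation on the pyrimidinylamino benzamide core

The compounds below may be only part of what the source reports. "The series", "measured", "known", "first", "only" and "open" are said of these compounds alone.

The series keeps one core and varies the aryl group on the sulfonyl sulfur. Compound 1 `Cc1cccc(S(=O)(=O)NCc2ccc(CNC(=O)c3ccc(CNc4ncccn4)cc3)cc2)c1` gives 100 nM in an assay on MDA-MB-231 cells for binding affinity to C-X-C chemokine receptor type 4 (Homo sapiens), read by microscopy, with stated times of 10 min and 30 min; on this read-out lower numbers stand for an effect already at smaller amounts and higher numbers for an effect only at larger amounts of compound. Compound 2 `O=C(NCc1ccc(CNS(=O)(=O)c2ccc(Cl)cc2)cc1)c1ccc(CNc2ncccn2)cc1` gives 100 nM, and the step of no change at the digits printed from compound 1 to compound 2 (within the scatter). Compound 3 `O=C(NCc1ccc(CNS(=O)(=O)c2ccc3c(c2)CCO3)cc1)c1ccc(CNc2ncccn2)cc1` gives 1000 nM; here the steps are a 10-fold higher number from compound 1 to compound 3 (1.00 log units; beyond the scatter) and a 10-fold higher number from compound 2 to compound 3 (1.00 log units; beyond the scatter). Compound 2 thus sits level with compound 1, together at the lowest numbers of the three, with compound 3 furthest away.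

Compound 4 `O=C(NCc1ccc(CNS(=O)(=O)c2ccc(-c3ccc(F)cc3)cc2)cc1)c1ccc(CNc2ncccn2)cc1` has not yet been measured. Its change from compound 2: 4-fluorophenyl in place of chloro on an aromatic carbon. Within the data shown here, no measured step exchanges a chloro for an aryl ring, so none bears directly on it. Among the measured compounds shown here, the only guidance is that the two small aryl groups of compound 1 and compound 2 gave the same number, while the larger nine-atom group of compound 3 gave a higher one, as a 10-fold higher number from compound 2 to compound 3 (1.00 log units; beyond the scatter) shows. Since 4-fluorophenyl also enlarges the group, a modest rise is expected for compound 4, a 3.0-fold higher number from compound 2 to compound 4 (0.48 log units; beyond the scatter). Compound 4 is therefore estimated at 300 nM, within 100 nM to 1000 nM.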

Compound 4, effective concentration (reported as EC, without a stated level of effect): 1000 nM
Beside the measured number, compound 4's estimate is 3.3-fold (0.52 log units) below it; low and high end bracket the measured number.
By their numbers in this assay, from the lowest: compounds 1 and 2 (each within the scatter of the next); then compounds 3 and 4 (each within the scatter of the next).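

Exchanging chloro for 4-fluorophenyl on this aromatic carbon, para to a large group, gives a 10-fold higher number from compound 2 to compound 4 (1.00 log units; beyond the scatter) in this assay, so this position does not keep the number of compound 2 once a second aromatic ring stands there. Two different enlargements of the sulfonyl aryl group now print the same value, with compound 3 at 1000 nM and compound 4 at 1000 nM, and among these four compounds neither of the two larger groups stays level with the smaller ones. Nothing available here explains the rise.

Open, on these data alone, is whether the rise comes with the added ring itself or with the fluorine on it, which an unsubstituted phenyl would separate. Also open, as far as these compounds go, is how a small group at this carbon, such as methoxy or an amine, would compare with chloro.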